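A few compounds are considered here, and "the series" means these few. Any claim that something is new, unique, unknown or untested is made for them only; others in the source may bear on it.

Of the compounds shown here, three sharing one core have been measured in a functional assay on HCT-116 cells (Homo sapiens) for cytotoxicity, read by MTT assay, with a stated time of 72 h; on this read-out lower numbers stand for stronger inhibition and higher numbers for weaker inhibition. Compound 1 `CC1(C)O[C@@H](CO)[C@H](Cn2cc(Cn3c4c(c5ccccc53)C(=O)c3c[n+]([O-])c5ccccc5c3C4=O)nn2)O1` gives 130 nM, the lowest of the three numbers and, in this read-out, the strongest inhibition. Compound 2 `CN(C)CCCCn1c2c(c3ccccc31)C(=O)c1c[n+]([O-])c3ccccc3c1C2=O` gives 450 nM, and compound 3 `CN(C)CCCCCn1c2c(c3ccccc31)C(=O)c1c[n+]([O-])c3ccccc3c1C2=O` gives 470 nM; the pair differ only in a saturated chain, and the step of a 1.0-fold higher number from compound 2 to compound 3 (0.02 log units; within the scatter) shows that lengthening that chain changes nothing worth noting.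

The next compound, compound 4 `O=C1c2c[n+]([O-])c3ccccc3c2C(=O)c2c1c1ccccc1n2Cc1cn([C@@H]2O[C@H](CO)[C@@H](O)[C@H](O)[C@H]2O)nn1`, keeps the core of compound 1 and alters only the group on the triazole nitrogen: 3,4,5-trihydroxy-6-(hydroxymethyl)oxan-2-yl in place of (5-(hydroxymethyl)-2,2-dimethyl-1,3-dioxolan-4-yl)methyl on an aromatic nitrogen. Among the compounds with values here, no measured step touches this part of the molecule, so the single known step, between compound 2 and compound 3, offers no guide to its effect. With the shared core unchanged, the expectation is a step of a 1.9-fold higher number from compound 1 to compound 4 (0.28 log units; within the scatter) of modest size in this assay, in either direction. Compound 4 is therefore estimated at 250 nM, with a range from 80 nM to 800 nM.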

Compound 4, half-maximal inhibitory concentration: 130 nM
For compound 4 the middle estimate is 1.9-fold (0.28 log units) above the measured one; low and high end bracket the measured number.
By their numbers in this assay, from the lowest: compounds 1 and 4 (each within the scatter of the next); then compounds 2 and 3 (each within the scatter of the next).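

In this assay, within the data shown here, the replacement of (5-(hydroxymethyl)-2,2-dimethyl-1,3-dioxolan-4-yl)methyl by 3,4,5-trihydroxy-6-(hydroxymethyl)oxan-2-yl on an aromatic nitrogen of the five-membered aromatic ring with 3 nitrogen gives no change at the digits printed from compound 1 to compound 4 (within the scatter) and is the first change read at this position. Here a five-membered non-aromatic ring with 2 hetero atoms gives way to a six-membered one with 1 hetero atom, and hydrogen-bond donors go from 1 to 4, yet the two numbers cannot be told apart. Nothing available explains why these two different groups give matching numbers.

Still open, on these data alone, is whether a small amine or a plain alkyl chain on that same nitrogen would also match compound 1 and compound 4. Also open, as far as these compounds go, is what a carboxylic acid in place of the hydroxymethyl on the oxane ring would do.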